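Branching the methoxymethyl group on a pyridine-bearing series

The source may hold more compounds than are shown below. What is called first, only, known or untested is meant among the compounds shown, and "the series" means these compounds.

Three compounds share one core and differ only in the group carried on the six-membered aromatic ring with one nitrogen. Compound 1 `Cc1cc(-c2noc([C@H](C)NC(=O)c3cc(C(F)(F)F)nn3C)n2)ccn1` gives 165 nM in an assay on T-REx-293 cells for inhibition of potassium channel subfamily T member 1 (Homo sapiens), read by patch clamp; a higher number here means a weaker inhibitor, a lower number a stronger inhibitor. Compound 2 `C[C@H](NC(=O)c1cc(C(F)(F)F)nn1C)c1nc(-c2ccnc(C3CC3)c2)no1` gives 16 nM. Compound 3 `COCc1cc(-c2noc([C@H](C)NC(=O)c3cc(C(F)(F)F)nn3C)n2)ccn1` gives 322 nM, which is the top end of the three numbers; the gap a 2.0-fold higher number from compound 1 to compound 3 (0.29 log units; within the scatter) is within the scatter, whereas a 20-fold higher number from compound 2 to compound 3 (1.30 log units; beyond the scatter) is far beyond it.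

Compound 4 `COC(C)(C)c1cc(-c2noc([C@H](C)NC(=O)c3cc(C(F)(F)F)nn3C)n2)ccn1` is built from compound 3 by 1-methoxy-1-methylethyl in place of methoxymethyl on an aromatic carbon. Among the measured compounds shown here, two measured steps bear on this. The step of a 10-fold lower number from compound 1 to compound 2 (1.01 log units; beyond the scatter) shows that a larger group at this position can go with a much lower number. The step of a 2.0-fold higher number from compound 1 to compound 3 (0.29 log units; within the scatter) shows that adding the methoxy group changed little. Compound 4 keeps the methoxy group of compound 3 but adds two methyls on the same chain carbon, making it bulkier in the direction that helped in compound 2, though the match is loose.

Compound 4 is therefore expected to show a moderately lower number than compound 3, a 2.5-fold lower number from compound 3 to compound 4 (0.39 log units; beyond the scatter), with an estimate of 130 nM and a likely range from 45 nM to 450 nM.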

Compound 4, half-maximal inhibitory concentration: 6280 nM
For compound 4 the middle estimate is 48-fold (1.68 log units) below the measured one, outside the stated range (above it).
By their numbers in this assay, from the lowest: compound 2; then compounds 1 and 3 (each within the scatter of the next); then compound 4.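

At this position, next to the ring nitrogen, a larger group does not by itself go with a lower number: putting two methyls on the chain carbon of compound 3 makes compound 4 the weakest inhibitor of the four in this assay (a 20-fold higher number from compound 3 to compound 4 (1.29 log units; beyond the scatter)), and the step from the small methyl group points the same way (a 38-fold higher number from compound 1 to compound 4 (1.58 log units; beyond the scatter)). The earlier compounds shown here left open whether groups larger than methyl would generally be favoured here, but compound 2 with its cyclopropyl now stands against compound 4 with its 1-methoxy-1-methylethyl, and this is the widest step in the set (a 390-fold higher number from compound 2 to compound 4 (2.59 log units; beyond the scatter)). So the shape of the group matters here, not only its heavy-atom count, and no measurement available here accounts for this change.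

The compounds shown leave open how a tert-butyl group, which keeps the branching without the oxygen, or a 1-methoxyethyl group, which carries one methyl on that chain carbon, would read. Also open, on these data alone, is how a 1-methoxycyclopropyl group would read, since it ties the two methyls into a ring and so shares a ring with the cyclopropyl of compound 2.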